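Sulfonyl substituent swap: expected stability of compound 4

The compounds below may be only part of what the source reports. "The series", "measured", "known", "first", "only" and "open" are said of these compounds alone.

Compound 3 `O=C(NS(=O)(=O)C1CC1)c1ccc(Nc2nc(NC3(c4ccc(Cl)cc4)CC3)nc(OCC(F)(F)F)n2)cc1` gives 100% in an ADME assay on microsomes from liver (Homo sapiens) for metabolic stability, with a stated time of 10 min (on this read-out higher numbers stand for a more stable compound and lower numbers for a less stable compound), level with compound 1 `O=C(NS(=O)(=O)c1ccc(F)cc1)c1ccc(Nc2nc(NC3(c4ccc(Cl)cc4)CC3)nc(OCC(F)(F)F)n2)cc1`, which gives 100%; together they are the highest of the three numbers, while compound 2 `CC(=O)NCCS(=O)(=O)NC(=O)c1ccc(Nc2nc(NC3(c4ccc(Cl)cc4)CC3)nc(OCC(F)(F)F)n2)cc1` gives 95%. The steps of no change at the digits printed from compound 1 to compound 3 (within the scatter), a number 5 percentage points lower from compound 1 to compound 2 (within the scatter) and a number 5 percentage points higher from compound 2 to compound 3 (within the scatter) all stay within the scatter. Compound 4 `NCCS(=O)(=O)NC(=O)c1ccc(Nc2nc(NC3(c4ccc(Cl)cc4)CC3)nc(OCC(F)(F)F)n2)cc1` carries the change (2-aminoethyl in place of cyclopropyl on a sulfonyl sulfur). Among the measured compounds shown here, the nearest precedent is compound 2, whose 2-acetamidoethyl on the sulfonyl sulfur is matched by a step within the scatter, and every measured change at this position has been within the scatter. No step beyond the scatter is therefore expected in this assay, in either direction. Compound 4 is estimated at 97%, with a range of 85% to 100%. The expected step is a number 3 percentage points lower from compound 3 to compound 4 (within the scatter), within the scatter.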

Compound 4, percent of the compound remaining: 100%
Compound 4: the middle estimate sits 3 percentage points below what was measured; the measured number falls inside the stated range.
By their numbers in this assay, from the lowest: compounds 2, 1, 3 and 4 (each within the scatter of the next).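

In this assay, the sulfonyl sulfur also accepts 2-aminoethyl, an open chain with no ring, with no change at the digits printed from compound 3 to compound 4 (within the scatter) and no change at the digits printed from compound 1 to compound 4 (within the scatter) as its steps. Hydrogen in place of acetyl on the amine nitrogen gives a number 5 percentage points higher from compound 2 to compound 4 (within the scatter) and so does not separate the free amine from the capped one on this read-out. Nothing available explains this result.

All four compounds lie within the scatter of each other, so no group shown here moves this read-out. Going by these compounds, whether a longer chain, a carboxylic acid or a tertiary amine on the sulfonyl sulfur would do so remains open.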